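The compounds below may be only part of what the source reports. "The series", "measured", "known", "first", "only" and "open" are said of these compounds alone.

Compound 1 `CC(C)c1onc(-c2c(Cl)cccc2Cl)c1COc1ccc(-c2nc3ccc(C(=O)O)cc3n2C)cc1` gives 7150 nM in an assay on HEK-293T cells for antagonist activity at vitamin D3 receptor (Homo sapiens), read by a luciferase reporter, with a stated time of 24 h; a higher number here means a weaker inhibitor, a lower number a stronger inhibitor.
Compound 2 `CCC(CC)n1c(-c2ccc(OCc3c(-c4c(Cl)cccc4Cl)noc3C(C)C)cc2)nc2ccc(C(=O)O)cc21` gives 5690 nM in this assay.
Compound 3 `CCCn1c(-c2ccc(OCc3c(-c4c(Cl)cccc4Cl)noc3C(C)C)cc2)nc2ccc(C(=O)O)cc21` gives 1400 nM in this assay.

Compound 3 has the lowest number of the three, with a 5.1-fold lower number from compound 1 to compound 3 (0.71 log units; beyond the scatter) and a 4.1-fold lower number from compound 2 to compound 3 (0.61 log units; beyond the scatter) both beyond the scatter. Compound 4 `CCCC(CCC)n1c(-c2ccc(OCc3c(-c4c(Cl)cccc4Cl)noc3C(C)C)cc2)nc2ccc(C(=O)O)cc21` differs from compound 3 by 1-propylbutyl in place of propyl on an aromatic nitrogen. The closest guide is a 4.1-fold lower number from compound 2 to compound 3 (0.61 log units; beyond the scatter), where a branched group on that aromatic nitrogen was exchanged for a straight one and the number fell. By contrast, a 1.3-fold lower number from compound 1 to compound 2 (0.10 log units; within the scatter) shows that a small and a branched group on the same nitrogen gave numbers within the scatter. Since compound 4 returns to a branched group, larger still, a modest rise in the number is expected, a 3.6-fold higher number from compound 3 to compound 4 (0.55 log units; beyond the scatter). Compound 4 is therefore estimated at 5000 nM, within 2000 nM to 12000 nM.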

Compound 4, half-maximal inhibitory concentration: > 10000 nM
Compound 4 was reported as a limit (the forecaster's own chance of this, stated with the estimate: 5%); at least 2.0-fold (0.30 log units) between middle value and limit.
By their numbers in this assay, from the lowest: compound 3; then compounds 2 and 1 (each within the scatter of the next). At a limit, above all of these: compound 4.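

Moving from propyl to 1-propylbutyl on this aromatic nitrogen gives an at least modest rise: an at least 7.1-fold higher number from compound 3 to compound 4 (0.85 log units; beyond the scatter). Compound 4 stands at a limit of the assay, not at a number: the limit of > 10000 nM in this assay, at which 1 of the 4 values shown sits. Neither an at least 1.3-fold higher number from compound 1 to compound 4 (0.14 log units; that floor lies within the scatter) nor an at least 1.7-fold higher number from compound 2 to compound 4 (0.24 log units; that floor lies within the scatter) can be read, as their floors lie within the scatter, so propyl alone stands apart here, with the lowest number of the four groups. Going by these compounds, a straight butyl chain, a cyclopentyl ring or a chain ending in an amine on this nitrogen remains open.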